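A Saturated Linker and a Morpholine Amide Awaiting Measurement

A few compounds are considered here, and "the series" means these few. Any claim that something is new, unique, unknown or untested is made for them only; others in the source may bear on it.

Three diarylurea compounds have so far been measured in a functional assay on HT-29 cells (Homo sapiens) for inhibition, read by MTT assay, with a stated time of 120 h; on this read-out higher numbers stand for weaker inhibition and lower numbers for stronger inhibition. Compound 1 `CNC(=O)/C=C/c1ccc(NC(=O)Nc2ccc(Cl)c(C(F)(F)F)c2)cc1` gives 11700 nM in this assay. Compound 2 `CC1CN(C(=O)/C=C/c2ccc(NC(=O)Nc3ccc(Cl)c(C(F)(F)F)c3)cc2)CC(C)O1` gives 9100 nM in this assay; it differs from compound 1 by 2,6-dimethylmorpholin-4-yl in place of methylamino on a carbonyl carbon, and the step is a 1.3-fold lower number from compound 1 to compound 2 (0.11 log units; within the scatter). Compound 3 `CNC(=O)CCc1ccc(NC(=O)Nc2ccc(Cl)c(C(F)(F)F)c2)cc1` gives 20600 nM in this assay; it differs from compound 1 by 2-(methylcarbamoyl)ethyl in place of 2-(methylcarbamoyl)ethenyl on an aromatic carbon, and the step is a 1.8-fold higher number from compound 1 to compound 3 (0.25 log units; within the scatter). Between compound 2 and compound 3 the gap lies beyond the usual scatter, but both of their steps from compound 1 lie within it.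

Compound 4 `CC1CN(C(=O)CCc2ccc(NC(=O)Nc3ccc(Cl)c(C(F)(F)F)c3)cc2)CC(C)O1` has not yet been measured in this assay. It differs from compound 3 by 2,6-dimethylmorpholin-4-yl in place of methylamino on a carbonyl carbon. This is the same kind of change as that from compound 1 to compound 2, though not the same: in compound 1 the carbonyl carbon that carries the change has a double-bonded chain carbon as its other neighbour, whereas in compound 3 that neighbour is a saturated chain carbon, as compound 4 inherits the linker of compound 3 rather than that of compound 1.

Going by the values given here, the expected step from compound 3 to compound 4 in this assay is a 1.3-fold lower number from compound 3 to compound 4 (0.11 log units; within the scatter), resting on the only precedent, compound 1 to compound 2, where the step was a 1.3-fold lower number from compound 1 to compound 2 (0.11 log units; within the scatter). Compound 4 is accordingly expected to give about 16000 nM in this assay, with a range from 7500 nM to 34000 nM.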

Compound 4, half-maximal inhibitory concentration: > 50000 nM
Compound 4 was reported as a limit (the forecaster's own chance of this, stated with the estimate: 5%); middle value at least 3.1-fold (0.49 log units) away from the limit.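

In this assay compound 4 gives > 50000 nM, which is a limit of the assay and not a number. On the core of compound 3, the change from methylamino to 2,6-dimethylmorpholin-4-yl on a carbonyl carbon gave an at least 2.4-fold higher number from compound 3 to compound 4 (0.38 log units; beyond the scatter), so it did not repeat what the same change did on the core of compound 1, and the two steps differ: the same change on two cores in this assay, a 1.3-fold lower number (0.11 log units; within the scatter) from compound 1 to compound 2 and an at least 2.4-fold higher number (0.38 log units; beyond the scatter) from compound 3 to compound 4, at least 3.1-fold (0.49 log units) apart, beyond the scatter of two such steps This shows that the effect of this change cannot simply be carried from one core to the other in this series, but it rests on one pair of cores, leaves the full size of the new step unknown and does not explain the difference, and one of the compounds stands at the limit: the limit of > 50000 nM in this assay, at which 1 of the 4 values shown sits.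

From the compounds shown here alone, it remains open whether a smaller amine such as dimethylamine, or a morpholine without the two methyl groups, on the carbonyl carbon of compound 3 would stay close to compound 3 or move towards compound 4. Also open, going by these compounds, is whether a longer saturated chain in place of the linker of compound 3 would respond to the same change as the core of compound 1 does or as the core of compound 3 does.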